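The source may report more compounds than this note shows. Statements on the series, on what has been measured and on what is new or still open speak of the compounds shown alone.

Working notes on the series.

Compound 1 `CC(C)N1CCc2nc(C#Cc3cccnc3)ccc2C1=O` carries an isopropyl group on the amide-type nitrogen of the shared core and a pyridinyl group on the triple-bonded carbon. In a functional assay on HEK293 cells for positive allosteric modulation of metabotropic glutamate receptor 5 (Homo sapiens), read by FLIPR and calcium flux (a lower number here means that less compound is needed, a higher number that more compound is needed for the effect), compound 1 gives "not active" (no number reported), so no number places it. Compound 2 `Cc1cccc(C#Cc2ccc3c(n2)CCN(C2CCCC2)C3=O)c1` gives 7.5 nM in this assay, and compound 3 `O=C1c2ccc(C#Cc3ccc(Cl)cc3)nc2CCN1C1CCCC1` gives 979 nM; the step of a 130-fold higher number from compound 2 to compound 3 (2.12 log units; beyond the scatter) shows that the group on the triple-bonded carbon moves the read-out strongly within this core.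

Compound 4 `O=C1c2ccc(C#Cc3cccnc3)nc2CCN1C1CCCCC1` differs from compound 1 by cyclohexyl in place of isopropyl on an amide-type nitrogen in a ring. No measured step changes the substituent on the amide-type nitrogen, so the size of this step is not anchored by any pair shown. Within the data shown here, the only step known, from compound 2 to compound 3, concerns a different position and does not bear directly on it. Compounds 2 and 3 both carry a five-membered carbon ring on that nitrogen and give numbers, whereas compound 1 with isopropyl gives none; a lower number for compound 4 than an inactive compound 1 is therefore expected, but with wide uncertainty. For compound 4 the value in this assay is estimated at 300 nM, within 30 nM to 10000 nM.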

Compound 4, half-maximal effective concentration: 387 nM
Beside the measured number, compound 4's estimate is 1.3-fold (0.11 log units) below it; low and high end bracket the measured number.
By their numbers in this assay, from the lowest: compound 2; then compound 4; then compound 3.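

Among these compounds, with compound 1 at "not active" (no number reported) in this assay, no step to compound 4 can be read, and no measured evidence bears on the result.

The compounds shown leave open how far cyclohexyl in place of isopropyl moves the read-out when the group on the triple-bonded carbon stays the same.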